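The source may report more compounds than this note shows. Statements on the series, on what has been measured and on what is new or still open speak of the compounds shown alone.

Compound 1 `CCCN(C(=O)CC(=O)O)C1=C(C)CC(c2ccccc2)N(CCCCN)C1=O`: 43 nM
Compound 2 `CCCN(C(=O)CC(=O)O)C1=C(C)CC(c2ccccc2)N(Cc2ccc(C(=N)N)cc2)C1=O`: > 1000000 nM
Compound 3 `CCCN(C(=O)CCC(=O)O)C1=C(C)CC(c2ccccc2)N(Cc2ccc(C(=N)N)cc2)C1=O`: not yet measured

In an assay on K562 cells for inhibition of integrin alpha-5/beta-1 (Homo sapiens) (on this read-out higher numbers stand for weaker inhibition and lower numbers for stronger inhibition), compound 1 gives 43 nM. Compound 2 gives only a limit, > 1000000 nM, so its true number is not known. The step of an at least 23000-fold higher number from compound 1 to compound 2 (4.36 log units; beyond the scatter) is therefore itself only a bound. Compound 3 differs from compound 2 by carboxymethyl in place of carboxy on a saturated chain carbon bound to a carbonyl carbon. Within the data shown here, no measured step touches this acid chain, so nothing among the measured compounds tells how large its effect is. Because compound 2 sits at the limit (the limit of > 1000000 nM in this assay, at which 1 of the 2 values shown sits), compound 3 is expected to stay there too, with an expected step of a number no higher from compound 2 to compound 3 (the limit leaves the size open). The estimate for compound 3 is 1000000 nM, between 100000 nM and 10000000 nM.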

Compound 3, half-maximal inhibitory concentration: > 1000000 nM
Compound 3 gave a limit, no number (the forecaster's own chance of this, stated with the estimate: 80%); the middle value sits exactly at the limit.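

Compound 2 and compound 3 each give only a limit, not a number, so the step between them cannot be read. The compounds shown leave open whether carboxymethyl in place of carboxy changes inhibition at all.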